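Replacing the hydroxy of compound 2 with methyl

The compounds below may be only part of what the source reports. "The series", "measured", "known", "first", "only" and "open" are said of these compounds alone.

Measured in a functional assay on MDA-MB-231 cells (Homo sapiens) for inhibition, read by MTT assay, with a stated time of 48 h; on this read-out lower numbers stand for stronger inhibition and higher numbers for weaker inhibition:
Compound 1 `COc1cc(-c2nccn3cc(-c4ccccc4)nc23)cc(OC)c1OC`: 364 nM
Compound 2 `COc1cc(-c2nccn3cc(-c4ccc(O)cc4)nc23)cc(OC)c1OC`: > 10000 nM

Compound 2 reads > 10000 nM, which is a limit of the assay and not a number. Compound 3 `COc1cc(-c2nccn3cc(-c4ccc(C)cc4)nc23)cc(OC)c1OC` is not yet measured in this assay. It carries methyl in place of hydroxy on an aromatic carbon, para to a large group: methyl in place of hydroxy on an aromatic carbon. For the measured compounds named here, one measured step bears on this change. Hydroxy in place of hydrogen on an aromatic carbon gave an at least 27-fold higher number from compound 1 to compound 2 (1.43 log units; beyond the scatter), a large step. As far as these compounds go, with the hydroxy gone, compound 3 is expected to lie much nearer compound 1 at 364 nM, although methyl itself remains untested here. A large step towards a lower number is therefore expected, estimated as an at least 20-fold lower number from compound 2 to compound 3 (1.30 log units; beyond the scatter). The estimate for compound 3 is 500 nM, with an expected range of 130 nM to 3000 nM.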

Compound 3, half-maximal inhibitory concentration: 53 nM
Compound 3: middle estimate off by 9.4-fold (0.97 log units), on the high side; the whole stated range lies above it.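

In this assay, for the compounds shown here, the earlier compounds left open whether any group on this aromatic carbon, para to a large group, would cost activity, yet methyl in place of hydrogen gives a 6.9-fold lower number from compound 1 to compound 3 (0.84 log units; beyond the scatter) and so improves on the unsubstituted compound. The identity of the group therefore decides the outcome at this place, with methyl in place of hydroxy giving an at least 180-fold lower number from compound 2 to compound 3 (2.27 log units; beyond the scatter) on the same carbon. As far as these compounds go, compound 2 stands at a limit of the assay and not at a number, so the full size of that step stays unknown: the limit of > 10000 nM in this assay, at which 1 of the 3 values shown sits.

From the compounds shown here alone, whether the gain belongs to methyl alone or extends to ethyl, chlorine or methoxy at this place remains open. So does whether an amine here would follow hydroxy or methyl.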